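This account rests on a few compounds, and the source may have more. Where it says the series, first, only, none or still open, it means among the compounds named here.

Three bromoacrylamides on the shared core have been run in a functional assay on HeLa cells (Homo sapiens) for inhibition, read by cell counting, with a stated time of 4 days; on this read-out higher numbers stand for weaker inhibition and lower numbers for stronger inhibition. Compound 1 `C=C(Br)C(=O)Nc1cccc(-c2cn3nc(Cc4cccc(OC)c4)sc3n2)c1` gives 2500 nM; compound 2 `C=C(Br)C(=O)Nc1cccc(-c2cn3nc(Cc4ccc(OC)cc4)sc3n2)c1` gives 2300 nM; compound 3 `C=C(Br)C(=O)Nc1cccc(-c2cn3nc(-c4ccc(Cl)cc4)sc3n2)c1` gives 3000 nM. The steps among them are small: a 1.1-fold lower number from compound 1 to compound 2 (0.04 log units; within the scatter), a 1.2-fold higher number from compound 1 to compound 3 (0.08 log units; within the scatter) and a 1.3-fold higher number from compound 2 to compound 3 (0.12 log units; within the scatter), so the three numbers sit together, and compound 3 holds the highest of the three without standing apart from either of the others.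

Compound 4 `C=C(Br)C(=O)Nc1cccc(-c2cn3nc(-c4ccccc4)sc3n2)c1` is the next analogue. Against compound 3 the change is hydrogen in place of chloro on an aromatic carbon. Among the measured compounds shown here, no measured step removes or adds a single group on the 4-chlorophenyl; the nearest comparisons, a 1.2-fold higher number from compound 1 to compound 3 (0.08 log units; within the scatter) and a 1.3-fold higher number from compound 2 to compound 3 (0.12 log units; within the scatter), exchange whole groups at the same attachment point on the core and both stay within the scatter. Nothing in the series therefore points to a step beyond the scatter in either direction. On that basis compound 4 is expected to give about 3500 nM, with a range from 1500 nM to 8000 nM. The step this estimate means, a 1.2-fold higher number from compound 3 to compound 4 (0.07 log units; within the scatter), is expected to lie within the scatter.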

Compound 4, half-maximal inhibitory concentration: 1400 nM
Compound 4: middle estimate off by 2.5-fold (0.40 log units), on the high side, and the stated range ends above it.
By their numbers in this assay, from the lowest: compounds 4, 2, 1 and 3 (each within the scatter of the next, the first and the last beyond it).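

Among the compounds shown here, replacing chloro with hydrogen on the aromatic carbon para to a large group gives the only step that lies beyond the scatter in this assay (a 2.1-fold lower number from compound 3 to compound 4 (0.33 log units; beyond the scatter)), so this position responds to a single-atom change, though modestly. The steps from the two methoxybenzyl compounds stay within the scatter (a 1.6-fold lower number from compound 2 to compound 4 (0.22 log units; within the scatter); a 1.8-fold lower number from compound 1 to compound 4 (0.25 log units; within the scatter)), so compound 4 stands apart from compound 3 alone. No measurement on these compounds accounts for the step.

Open, as far as these compounds go, is whether this step belongs to chloro in particular or would recur with fluoro, methyl or an amine on the same carbon. Also open, from the compounds shown here alone, is how an unsubstituted benzyl at the same attachment point would compare with the phenyl of compound 4 and with the two methoxybenzyl compounds.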